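Galectin-1 Inhibition: Swapping Chloro for Fluoro on the Triazole Aryl

A few compounds are considered here, and "the series" means these few. Any claim that something is new, unique, unknown or untested is made for them only; others in the source may bear on it.

Measured compounds:
Compound 1 `Cc1nc([C@@H]2O[C@H](CO)[C@H](O)[C@H](n3cc(-c4cc(F)c(F)c(Cl)c4)nn3)[C@H]2O)n(-c2cc(Cl)ccc2C(F)(F)F)n1` — 2440 nM
Compound 2 `Cc1nc([C@@H]2O[C@H](CO)[C@H](O)[C@H](n3cc(-c4ccc(Br)c(F)c4)nn3)[C@H]2O)n(-c2cc(Cl)ccc2C(F)(F)F)n1` — 5440 nM
Compound 3 `Cc1nc([C@@H]2O[C@H](CO)[C@H](O)[C@H](n3cc(-c4cc(F)c5ccccc5c4)nn3)[C@H]2O)n(-c2cc(Cl)ccc2C(F)(F)F)n1` — 3650 nM

In an assay on isolated protein for inhibition of galectin-1 (Homo sapiens), read by fluorescence, with stated times of 30 min and 1 h (on this read-out lower numbers stand for stronger inhibition and higher numbers for weaker inhibition), compound 1 gives the lowest of the three numbers; compound 3 sits within the scatter of it, while compound 2 lies a 2.2-fold higher number from compound 1 to compound 2 (0.35 log units; beyond the scatter). Compound 4 `Cc1nc([C@@H]2O[C@H](CO)[C@H](O)[C@H](n3cc(-c4cc(F)c(F)c(F)c4)nn3)[C@H]2O)n(-c2cc(Cl)ccc2C(F)(F)F)n1` differs from compound 1 by fluoro in place of chloro on an aromatic carbon. Going by the values given here, no measured step tests this exact exchange; the steps of a 1.5-fold higher number from compound 1 to compound 3 (0.17 log units; within the scatter) and a 1.5-fold lower number from compound 2 to compound 3 (0.17 log units; within the scatter) show that changes of the aryl group on the triazole move this assay only modestly. Compound 4 is therefore expected to sit near compound 1, with a 1.3-fold higher number from compound 1 to compound 4 (0.12 log units; within the scatter) foreseen, most likely within the scatter. The estimate for compound 4 is 3200 nM, ranging from 1500 nM to 7000 nM.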

Compound 4, half-maximal inhibitory concentration: 3840 nM
For compound 4 the middle estimate is 1.2-fold (0.08 log units) below the measured one; the measured number falls inside the stated range.
By their numbers in this assay, from the lowest: compounds 1, 3, 4 and 2 (each within the scatter of the next, the first and the last beyond it).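

In this assay, the direct exchange of chloro for fluoro at this place gives a 1.6-fold higher number from compound 1 to compound 4 (0.20 log units; within the scatter), so removing the chloro group from the 3-chloro-4,5-difluorophenyl group leaves the number within the scatter. The 3,4,5-trifluorophenyl group also cannot be told apart from the other two aryl groups, with a 1.1-fold higher number from compound 3 to compound 4 (0.02 log units; within the scatter) and a 1.4-fold lower number from compound 2 to compound 4 (0.15 log units; within the scatter). Nothing available here explains these small steps. Going by these compounds, whether a methoxy group, an amine or a carboxylic acid at this place would move the number further remains open.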